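Chlorophenyl position on the piperazine side chain

The compounds below may be only part of what the source reports. "The series", "measured", "known", "first", "only" and "open" are said of these compounds alone.

Measured compounds:
compound 1, `CCC1(CCCCN2CCN(c3ccc(Cl)cc3)CC2)C(=O)Nc2ccccc21`: 10 mg/kg
compound 2, `CCC1(CCCCN2CC=C(c3ccc(Cl)cc3)CC2)C(=O)Nc2ccccc21`: > 20 mg/kg, a limit of the assay

For the measured compounds named here, in a functional assay on the whole organism (strain Wistar) with Rattus norvegicus as the target, with a stated time of 5 min (a lower number here means that less compound is needed, a higher number that more compound is needed for the effect), compound 1 gives 10 mg/kg, the only numerical value in the set. For compound 2 the result is > 20 mg/kg, which is a limit and not a number; within the set that amounts to the limit of > 20 mg/kg in this assay, at which 1 of the 2 values shown sits. Going by the values given here, compound 1 therefore stands as the single point from which the series can be read, with no measured pair that differs in one place to set a scale.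

Compound 3, `CCC1(CCCCN2CCN(c3cccc(Cl)c3)CC2)C(=O)Nc2ccccc21`, keeps the whole of compound 1 except for the change (3-chlorophenyl in place of 4-chlorophenyl on an amine nitrogen in a ring). The two compounds hold the same atoms joined differently, so the comparison rests entirely on where the chlorine sits on the aromatic ring that hangs from the amine nitrogen in a ring.

Among the compounds with values here, no measured step of this kind exists here, so the expectation must be set without a precedent. The step from compound 1 to compound 3 is expected to be small, at most a modest move towards more compound being needed, a 1.5-fold higher number from compound 1 to compound 3 (0.18 log units; within the scatter). Compound 3 is accordingly estimated at 15 mg/kg, with a range from 5 mg/kg to 40 mg/kg.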

Compound 3, minimum effective dose: > 20 mg/kg
Compound 3 ended at the assay's limit; the forecaster's own chance of this, stated with the estimate: 30%; at least 1.3-fold (0.12 log units) between middle value and limit.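

Replacing 4-chlorophenyl with 3-chlorophenyl on the amine nitrogen in a ring gives the series its first comparison that differs in one place: in this assay, the change amounts to an at least 2.0-fold higher number from compound 1 to compound 3 (0.30 log units; that floor lies within the scatter). From the compounds shown here alone, compound 3 gives > 20 mg/kg, which is a limit of the assay and not a number, so only the floor of this step can be read and its true size remains unknown. Compound 1 remains the only compound in the set with a numerical value, and the series now has one fixed point, with the other compounds sitting at the same limit: the limit of > 20 mg/kg in this assay, at which 2 of the 3 values shown sit.

The compounds shown leave open how an unsubstituted phenyl, a fluorophenyl or a methoxyphenyl on the same nitrogen would read in this assay, and so whether the chlorine contributes to the value of compound 1 at all. Also open, going by these compounds, is whether a shorter or longer chain between the shared core and the amine nitrogen in a ring would keep the 4-chlorophenyl compound measurable or move it to the limit as well.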